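The source may report more compounds than this note shows. Statements on the series, on what has been measured and on what is new or still open speak of the compounds shown alone.

In a functional assay on NCI-H23 cells (Homo sapiens) for inhibition, read by sulforhodamine B assay, with a stated time of 48 h (on this read-out higher numbers stand for weaker inhibition of growth and lower numbers for stronger inhibition of growth), compound 1 `O=C(Cc1csc2nc(-c3ccc(Br)cc3)cn12)N/N=C/c1ccc(O)cc1` gives 32400 nM, and compound 2 `COc1cccc(OC)c1/C=N/NC(=O)Cc1csc2nc(-c3ccc(Br)cc3)cn12` gives 52500 nM, so the two cannot be told apart. Compound 3 `O=C(Cc1csc2nc(-c3ccc(Br)cc3)cn12)N/N=C/c1ccc(Cl)cc1Cl` has not yet been measured. It differs from compound 1 by 2,4-dichlorophenyl in place of 4-hydroxyphenyl on a carbon with a double bond to nitrogen, with 2,4-dichlorophenyl in place of 4-hydroxyphenyl on a carbon with a double bond to nitrogen. For the measured compounds named here, only one measured step changes the group at that place, a 1.6-fold higher number from compound 1 to compound 2 (0.21 log units; within the scatter), so no step beyond the scatter is expected in this assay. The expected step is a 1.1-fold higher number from compound 1 to compound 3 (0.03 log units; within the scatter). Compound 3 is estimated at 35000 nM, with an expected range of 15000 nM to 80000 nM.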

Compound 3, concentration for total growth inhibition: 56200 nM
Beside the measured number, compound 3's estimate is 1.6-fold (0.21 log units) below it; the range from low to high includes it.
By their numbers in this assay, from the lowest: compounds 1, 2 and 3 (each within the scatter of the next).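

A third group at this place, 2,4-dichlorophenyl, gives a 1.7-fold higher number from compound 1 to compound 3 (0.24 log units; within the scatter) and also a 1.1-fold higher number from compound 2 to compound 3 (0.03 log units; within the scatter) in this assay. The change from compound 1 to compound 3 removes the hydrogen-bond donor and acceptor of 4-hydroxyphenyl, yet the step stays within the scatter, so all three groups at this place remain indistinguishable. No measurement shown here bears on why this is so.

As far as these compounds go, it remains open whether a group other than a substituted phenyl, such as a pyridine ring or a short alkyl chain, would give a step beyond the scatter. An amine or a carboxylic acid on the phenyl ring is equally untested in what is shown.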